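A halogen exchange on the 3-chlorophenyl group

A few compounds are considered here, and "the series" means these few. Any claim that something is new, unique, unknown or untested is made for them only; others in the source may bear on it.

Compound 1 `COc1ccccc1Oc1c(N)nc(-c2ccccc2)nc1OCCO` gives > 80000 nM in a functional assay on SK-MEL-28 cells (Homo sapiens) for cytotoxicity, read by CCK-8 assay, with a stated time of 24 h (a higher number here means a weaker inhibitor, a lower number a stronger inhibitor), which is a limit of the assay and not a number. In this assay compound 2 `COc1ccccc1Oc1c(N)nc(-c2ccc(F)cc2)nc1OCCO` gives 20100 nM, and compound 3 `COc1ccccc1Oc1c(N)nc(-c2cccc(Cl)c2)nc1OCCO` gives 4170 nM, the lowest number of the three. Fluoro in place of hydrogen produced an at least 3.9-fold lower number from compound 1 to compound 2 (0.59 log units; beyond the scatter), and chloro in place of hydrogen produced an at least 19-fold lower number from compound 1 to compound 3 (1.28 log units; beyond the scatter). The move to 3-chlorophenyl in place of 4-fluorophenyl produced a 4.8-fold lower number from compound 2 to compound 3 (0.68 log units; beyond the scatter). Compound 4 `COc1ccccc1Oc1c(N)nc(-c2cccc(I)c2)nc1OCCO` departs from compound 3 by one exchange, (iodo in place of chloro on an aromatic carbon), with iodo in place of chloro on an aromatic carbon. Among the compounds with values here, no measured compound carries iodo, so these steps bear on the change only indirectly. All of them run toward lower numbers, which suggests the same direction here, though with a smaller size. The expected step is a 1.4-fold lower number from compound 3 to compound 4 (0.14 log units; within the scatter), a small one that would probably stay within the scatter. Compound 4 is estimated at 3000 nM, with an expected range of 1200 nM to 8000 nM.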

Compound 4, half-maximal inhibitory concentration: 11200 nM
The estimate for compound 4 lay 3.7-fold (0.57 log units) below the measured number; the whole stated range lies below it.
By their numbers in this assay, from the lowest: compound 3; then compounds 4 and 2 (each within the scatter of the next). At a limit, above all of these: compound 1.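

In this assay, the exchange of 3-chlorophenyl for 3-iodophenyl is the first change among these compounds to run toward a higher number (a 2.7-fold higher number from compound 3 to compound 4 (0.43 log units; beyond the scatter)), so chloro and iodo on this carbon are not interchangeable. Iodo still gives a lower number than hydrogen (an at least 7.1-fold lower number from compound 1 to compound 4 (0.85 log units; beyond the scatter)), while the 3-iodophenyl and 4-fluorophenyl compounds cannot be separated (a 1.8-fold lower number from compound 2 to compound 4 (0.25 log units; within the scatter)). Going by these compounds, the step from hydrogen stays open-ended, as compound 1 stands at a limit of the assay and not at a number: the limit of > 80000 nM in this assay, at which 1 of the 4 values shown sits.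

On these data alone, whether bromo on this same carbon would track chloro or iodo remains open, as does how a methoxy or nitrile group would compare there. Also open, as far as these compounds go, is how 3-fluorophenyl would stand, which leaves the choice of halogen and its place tangled in the step from compound 2 to compound 3.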